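This account rests on a few compounds, and the source may have more. Where it says the series, first, only, none or still open, it means among the compounds named here.

Compound 1, `CCOC(=O)c1ccc(-c2nn(C)c3ccccc23)cc1`. In a functional assay on cells (Platelet, Homo sapiens) for inhibition (a higher number here means a weaker inhibitor, a lower number a stronger inhibitor), compound 1 gives > 10000 nM, which is a limit of the assay rather than a number.
Compound 2, `CCOC(=O)c1ccc(-c2nn(Cc3ccc(OC)cc3)c3ccccc23)cc1`. In this assay compound 2 gives > 10000 nM, likewise a limit.

Among the compounds with values here, compound 1 therefore stands only at a limit, and the one other value shown is a limit as well. The step that the two limits leave unreadable from compound 1 to compound 2 is unreadable because the limit of > 10000 nM in this assay, at which 2 of the 2 values shown sit, holds at both of its ends. Compound 3, `CCCCn1nc(-c2ccc(C(=O)OCC)cc2)c2ccccc21`, differs from compound 1 by propyl in place of hydrogen on a saturated chain carbon bound to an aromatic nitrogen. Within the data shown here, the only measured step at the same place, the one from compound 1 to compound 2, gives no size and no direction to carry over. With the limit of > 10000 nM in this assay, at which 2 of the 2 values shown sit, describing every value shown, compound 3 is expected to sit at that limit as well. Compound 3 is expected to give 20000 nM in this assay, within a range from 5000 nM to 100000 nM. The step that the limit leaves unreadable from compound 1 to compound 3 is expected to stay within the usual scatter.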

Compound 3, half-maximal inhibitory concentration: > 10000 nM
Compound 3: a limit, no number; the forecaster's own chance of this, stated with the estimate: 80%; the middle value is on the limit's open side.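

Within the data shown here, no step among compound 1, compound 2 and compound 3 can be read, because all three stand at a limit of the assay: the limit of > 10000 nM in this assay, at which 3 of the 3 values shown sit. Still open, going by these compounds, is whether any group on the saturated chain carbon bound to an aromatic nitrogen gives in this assay a true number rather than a limit.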